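The compounds below may be only part of what the source reports. "The series", "measured", "known", "first", "only" and "open" are said of these compounds alone.

Measured so far in a functional assay for agonist activity at G protein-coupled receptor 88 (Homo sapiens), read by HTRF and cAMP accumulation; a lower number here means that less compound is needed, a higher number that more compound is needed for the effect:
- compound 1, `CC(C)C[C@H](N)CN(C(=O)[C@@H]1C[C@H]1c1ccccc1)c1ccc(-c2ccccc2)cc1`, gives 880 nM
- compound 2, `COc1cccc(-c2ccc(N(C[C@@H](N)CC(C)C)C(=O)[C@@H]3C[C@H]3c3ccccc3)cc2)c1`, gives 1100 nM

For the measured compounds named here, of these two numbers, the one for compound 2 lies on the high side, but the single measured step, a 1.3-fold higher number from compound 1 to compound 2 (0.10 log units; within the scatter), is within the scatter, so the two compounds are not separated by this read-out. Nothing else in the set bears on the substituent pattern of the outer ring.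

Compound 3, `CC(C)C[C@H](N)CN(C(=O)[C@@H]1C[C@H]1c1ccccc1)c1ccc(-c2ccccc2Cl)cc1`, differs from compound 2 by 2-chlorophenyl in place of 3-methoxyphenyl on an aromatic carbon. Two parts of that change can be weighed. Going by the values given here, removing the methoxy simply reverses the one measured step, a 1.3-fold higher number from compound 1 to compound 2 (0.10 log units; within the scatter), which was within the scatter; the chlorine then enters at a place on the ring that no measured compound has probed, so there is no step to draw on for it. Among the compounds with values here, with the only relevant evidence pointing to a flat response, a step beyond the scatter is not expected in either direction, and the uncertainty is set wide to cover the unprobed chlorine.

For compound 3 in this assay the estimate is 900 nM, with a range of 350 nM to 2500 nM. That estimate corresponds to an expected step of a 1.2-fold lower number from compound 2 to compound 3 (0.09 log units; within the scatter).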

Compound 3, half-maximal effective concentration: 3800 nM
Beside the measured number, compound 3's estimate is 4.2-fold (0.63 log units) below it; measured number outside the range, above it.
By their numbers in this assay, from the lowest: compounds 1 and 2 (each within the scatter of the next); then compound 3.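

Unlike the methoxy change, where a 1.3-fold higher number from compound 1 to compound 2 (0.10 log units; within the scatter) left compounds 1 and 2 unseparated in this assay, this terminal aromatic ring now shows that its substitution can matter. Chloro in place of hydrogen gives a 4.3-fold higher number from compound 1 to compound 3 (0.64 log units; beyond the scatter) and 2-chlorophenyl in place of 3-methoxyphenyl gives a 3.5-fold higher number from compound 2 to compound 3 (0.54 log units; beyond the scatter) in the same read-out, so the ring is not indifferent to every substituent, although both steps are modest. The data hold no measurement that accounts for this rise.

Compound 3 differs from compound 1 in a single chlorine, while its difference from compound 2 changes both the substituent and where it sits on the ring, so the compounds shown do not separate the effect of chlorine itself from that of its place. Also open, as far as these compounds go, is whether a nitrile, a carboxylic acid or an aminomethyl group in place of the chlorine would give a step of similar size, or would stay within the scatter as the methoxy did.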